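This account rests on a few compounds, and the source may have more. Where it says the series, first, only, none or still open, it means among the compounds named here.

For the measured compounds named here, in a functional assay on NCI-H460 cells (Homo sapiens) for cytotoxicity, read by MTT assay, with a stated time of 72 h (a lower number here means a stronger inhibitor, a higher number a weaker inhibitor), compound 2 `Cc1cc(/C=N/NC(=O)Nc2ccc(Oc3ccnc(-c4nncn4CCN(C)C)c3)c(F)c2)cc(C)c1O` gives 2010 nM, the lowest of the two numbers so far, with compound 1 `CN(C)CCn1cnnc1-c1cc(Oc2ccc(NC(=O)N/N=C/c3ccc(O)c(F)c3)cc2F)ccn1` at 2620 nM within the scatter of it. Compound 3 `CN(C)CCn1cnnc1-c1cc(Oc2ccc(NC(=O)N/N=C/c3c(Cl)cccc3Cl)cc2F)ccn1` differs from compound 2 by 2,6-dichlorophenyl in place of 4-hydroxy-3,5-dimethylphenyl on a carbon with a double bond to nitrogen. Going by the values given here, the only step that bears on this change is a 1.3-fold lower number from compound 1 to compound 2 (0.12 log units; within the scatter), which also altered the substituents on this same aromatic ring and stayed within the scatter. Compound 3 is therefore expected to show no step beyond the scatter, a 1.2-fold higher number from compound 2 to compound 3 (0.09 log units; within the scatter), and its estimated value in this assay is 2500 nM, between 900 nM and 7000 nM.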

Compound 3, half-maximal inhibitory concentration: 350 nM
Compound 3: the middle estimate sits 7.1-fold (0.85 log units) above what was measured; the measured number lies below the stated range.
By their numbers in this assay, from the lowest: compound 3; then compounds 2 and 1 (each within the scatter of the next).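

In this assay, the group on the carbon with a double bond to nitrogen now proves able to move the number beyond the scatter: 2,6-dichlorophenyl gives a 5.7-fold lower number from compound 2 to compound 3 (0.76 log units; beyond the scatter) and a 7.5-fold lower number from compound 1 to compound 3 (0.87 log units; beyond the scatter). The two hydroxy-bearing phenyl groups had not separated, so the change that matters here is the full exchange for the dichlorinated ring. Nothing measured here accounts for this step.

The compounds shown leave open whether the chlorines or the loss of the hydroxy group carries the step. A 2,6-dimethylphenyl or a 2-chlorophenyl group at this place would separate the two.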